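A few compounds are considered here, and "the series" means these few. Any claim that something is new, unique, unknown or untested is made for them only; others in the source may bear on it.

Within the data shown here, in a functional assay on MLM cells (Homo sapiens) for cytotoxicity, using microsomes (on this read-out higher numbers stand for an effect only at larger amounts of compound and lower numbers for an effect already at smaller amounts), compound 3 `CCCOc1ccc(/C=C\c2cc(OC)c(OC)c(OC)c2)cc1` gives 6.5 uM, the only actual number among the measured compounds. Compound 1 `COc1cc(/C=C/c2ccc(C(C)C)cc2)cc(OC)c1OC` gives > 25 uM, which is a limit of the assay. Compound 2 `COc1cc(/C=C/c2ccc(C(C)(C)C)cc2)cc(OC)c1OC` gives > 25 uM, again a limit. Compound 4 `CCCOc1ccc(/C=C/c2cc(OC)c(OC)c(OC)c2)cc1` differs from compound 3 only in its geometry: the two compounds have the same atoms and bonds and differ only in configuration as drawn: 1 of 1 stereo elements differ; a double bond is drawn Z in compound 3 and E in compound 4. Among the measured compounds shown here, the sole measured step, a step that the two limits leave unreadable from compound 1 to compound 2, leaves the double bond untouched and offers no size to carry over. Compounds 1 and 2 have the double bond drawn E, as compound 4 does, though they differ from it elsewhere, and both sit at the limit. On that slender basis, an upward step is expected in this assay, estimated as a 4.6-fold higher number from compound 3 to compound 4 (0.66 log units; beyond the scatter). For compound 4 the expected value is 30 uM, with an estimated range of 10 uM to 100 uM.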

Compound 4, concentration for half-maximal effect: > 25 uM
Compound 4 was reported as a limit; the forecaster's own chance of this, stated with the estimate: 70%; the middle value is on the limit's open side.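

In this assay, the configuration of the double bond alone separates the pair, as the change from Z to E gives an at least 3.8-fold higher number from compound 3 to compound 4 (0.58 log units; beyond the scatter). This is the first readable step among these compounds, and it can be assigned to geometry with no other change involved: the fact that compounds 3 and 4 differ only in the configuration as drawn The steps to compound 4 from compound 1 and from compound 2 cannot be read: the limit of > 25 uM in this assay, at which 3 of the 4 values shown sit.

From the compounds shown here alone, how far the true value of compound 4 lies past its limit remains open, so the full size of the step is unknown. Also open, going by these compounds, is whether a Z double bond gives a similar number with a butoxy chain or an amine in place of propoxy.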